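The source may hold more compounds than are shown below. What is called first, only, known or untested is meant among the compounds shown, and "the series" means these compounds.

In a functional assay on UACC-257 cells (Homo sapiens) for inhibition, read by sulforhodamine B assay, with a stated time of 48 h (on this read-out higher numbers stand for lower toxicity in this test and lower numbers for higher toxicity in this test), compound 1 `Nc1cc(N)c2nc(-c3ccccc3)c(Oc3ccc(Cl)c(Cl)c3)nc2c1` gives only a limit, < 100000 nM, so where it stands on this scale is not known beyond that. Two other compounds give numbers in this assay: compound 2 `CCOC(=O)[C@H](CCC(=O)O)NC(=O)c1ccc(Sc2nc3cc(N)cc(N)c3nc2-c2ccccc2)cc1` gives 95500 nM, and compound 3 `COc1ccc(CNc2nc3cc(N)cc(N)c3nc2-c2ccccc2)cc1` gives 56200 nM. Compound 4 `COc1ccc(Sc2nc3cc(N)cc(N)c3nc2-c2ccccc2)cc1` has not yet been measured; it differs from compound 1 by (4-methoxyphenyl)sulfanyl in place of 3,4-dichlorophenoxy on an aromatic carbon. Within the data shown here, no step between two measured compounds is available, and for compound 1 only the limit of < 100000 nM in this assay, at which 1 of the 3 values shown sits, is known, so the size of the change cannot be read off directly. Compound 4 shares the sulfanyl linkage with compound 2, and in this assay compound 2 gives 95500 nM. For compound 4 the estimate in this assay is 65000 nM, expected to lie between 20000 nM and 150000 nM. The expected step from compound 1 to compound 4 is a step that the limit leaves unreadable from compound 1 to compound 4, with no clear direction beyond the scatter.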

Compound 4, concentration lethal to 50% of the cells: < 100000 nM
Compound 4 was reported as a limit; the forecaster's own chance of this, stated with the estimate: 35%; the middle value does not contradict the limit.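

No step from compound 1 to compound 4 can be read in this assay, since each of the two is reported only as a limit: the limit of < 100000 nM in this assay, at which 2 of the 4 values shown sit.

The compounds shown leave open whether (4-methoxyphenyl)sulfanyl in place of 3,4-dichlorophenoxy changes the read-out at all, and in which direction.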